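A few compounds are considered here, and "the series" means these few. Any claim that something is new, unique, unknown or untested is made for them only; others in the source may bear on it.

Four related compounds share a chain that joins two aromatic ends. Compound 1 `COc1ccc(/C=C/C=C/C(=O)c2ccc(C)s2)cc1` has no reported result in an ADME assay on RAW264.7 cells (Mus musculus) for cytotoxicity, read by MTT assay (on this read-out lower numbers stand for stronger inhibition and higher numbers for weaker inhibition), shown only as "not determined" (no result reported). Compound 2 `O=C(/C=C/C=C/c1ccc(O)cc1O)c1ccc(O)cc1` and compound 3 `COc1ccc(/C=C/C=C/C(=O)c2ccc(O)cc2)c(O)c1` were both tested in this assay. There compound 3 reaches only a limit of the assay, > 100000 nM. For compound 2 the same this assay likewise reports only a limit, > 100000 nM. The change from compound 3 to compound 2 hydrogen in place of methyl on an oxygen on an aromatic ring therefore gives a step that the two limits leave unreadable from compound 3 to compound 2. Compound 4 `Cc1ccc(C(=O)/C=C/C=C/c2ccc(O)cc2)s1` arises from compound 1 by the same change (hydrogen in place of methyl on an oxygen on an aromatic ring), made at the same kind of place. How the core of compound 1 differs from that of compound 3 is not broken down here. Because (the limit of > 100000 nM in this assay, at which 2 of the 3 values shown sit), compound 4 is expected to sit around 150000 nM in this assay, estimated between 50000 nM and 500000 nM, most likely again as a limit rather than a number.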

Compound 4, half-maximal inhibitory concentration: 28300 nM
Estimate against measurement, compound 4: 5.3-fold (0.72 log units) above; the whole stated range lies above it.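

No new step can be read: compound 4 pairs only with compound 1, which stands as "not determined" (no result reported). The compounds shown leave open how much going from methoxy to hydroxy shifts cytotoxicity on the core of compound 1.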